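This account rests on a few compounds, and the source may have more. Where it says the series, first, only, none or still open, it means among the compounds named here.

Working notes on the series. Compound 1 `CCCCCCCCCCc1cc2cn([C@H]3C[C@H](O)[C@@H](CO)O3)c(=O)nc2o1` is the reference point. In a functional assay for cytotoxicity, read by microscopy (a lower number here means that less compound is tolerated, a higher number that more compound is tolerated), compound 1 gives only a limit, > 50000 nM. This is the point noted as the limit of > 50000 nM in this assay, at which 1 of the 2 values shown sits. Compound 2 `O=c1[nH]c(=O)n([C@H]2C[C@H](O)[C@@H](CO)O2)cc1C#CCCCCCCCCCF`, built on a different core, is the other measured member. In this assay compound 2 gives 200000 nM, a number rather than a limit. Among the measured compounds shown here, no pair of measured compounds differs in a single place, so nothing about the size of effect of any one change has been measured in this set. Compound 3 `O=c1nc2oc(CCCCCCCCCF)cc2cn1[C@H]1C[C@H](O)[C@@H](CO)O1` is the unmeasured member. The change from compound 1 to compound 3 is fluoro in place of methyl on a saturated chain carbon, nine bonds along the chain from an aromatic carbon. With compound 1 known only as a limit, no direction for the step can be read from the numbers, and in this assay the expected step is a step that the limit leaves unreadable from compound 1 to compound 3, which amounts to none beyond the scatter. Compound 3 is therefore expected to give about 100000 nM in this assay, within 30000 nM to 400000 nM, and it may well be reported again only as a limit.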

Compound 3, minimum cytotoxic concentration: > 50000 nM
Compound 3 ended at the assay's limit (the forecaster's own chance of this, stated with the estimate: 60%); the middle value is on the limit's open side.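

Compound 1 and compound 3 both sit at a limit rather than at a number, so no step can be read between them: the limit of > 50000 nM in this assay, at which 2 of the 3 values shown sit.

The compounds shown leave open whether fluoro in place of methyl on a saturated chain carbon, nine bonds along the chain from an aromatic carbon, shifts the read-out in this assay at all, and in which direction.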